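Acetyl for methyl on the urea-bound phenyl ring

A few compounds are considered here, and "the series" means these few. Any claim that something is new, unique, unknown or untested is made for them only; others in the source may bear on it.

Measured compounds:
Compound 1 `Cc1cccc(NC(=O)Nc2cc(Oc3ccc4nc(NC(=O)C5CC5)sc4c3)ccc2F)c1` — in a functional assay on HT-29 cells (Homo sapiens) for inhibition, read by luminescence and CellTiter-Glo, with a stated time of 12 h (a higher number here means that more compound is needed for the effect, a lower number that less compound is needed), compound 1 gives 580 nM.
Compound 2 `CCOC(=O)c1cccc(NC(=O)Nc2cc(Oc3ccc4nc(NC(=O)C5CC5)sc4c3)ccc2F)c1` — in this assay compound 2 gives 7740 nM.
Compound 3 `O=C(Nc1nc2ccc(Oc3ccc(F)c(NS(=O)(=O)c4cccc(C(F)(F)F)c4)c3)cc2s1)C1CC1` — in this assay compound 3 reaches only the assay limit, > 20000 nM.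

Compound 1 holds the lowest of the two numbers reported; the nearest is compound 2. The value of compound 3 is a limit and not a number, namely (the limit of > 20000 nM in this assay, at which 1 of the 3 values shown sits), and it sits outside any comparison of size.

Compound 4 `CC(=O)c1cccc(NC(=O)Nc2cc(Oc3ccc4nc(NC(=O)C5CC5)sc4c3)ccc2F)c1` is not yet measured. It differs from compound 1 in one place: acetyl in place of methyl on an aromatic carbon. Going by the values given here, only one measured step bears on it, the one where a 13-fold higher number from compound 1 to compound 2 (1.13 log units; beyond the scatter); there the group brought in at the same place also carries a carbonyl, and the number rose well beyond the scatter. The acetyl of compound 4 is a smaller version of that change, so a rise in the number from compound 1 is expected, likely smaller than that of compound 2. The expected step is a 4.3-fold higher number from compound 1 to compound 4 (0.63 log units; beyond the scatter). Compound 4 is thus estimated at 2500 nM in this assay, within 800 nM to 8000 nM.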

Compound 4, half-maximal effective concentration: 1000 nM
Beside the measured number, compound 4's estimate is 2.5-fold (0.40 log units) above it; the measured number falls inside the stated range.
By their numbers in this assay, from the lowest: compounds 1 and 4 (each within the scatter of the next); then compound 2. At a limit, above all of these: compound 3.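

In this assay acetyl in place of methyl on this aromatic carbon gives a 1.7-fold higher number from compound 1 to compound 4 (0.24 log units; within the scatter), so a carbonyl attached directly at this position is tolerated within the scatter. With the carbonyl kept and ethoxy replaced by methyl, the step is a 7.7-fold lower number from compound 2 to compound 4 (0.89 log units; beyond the scatter), which ties the rise seen for compound 2 to the ethoxy on the carbonyl carbon and not to the carbonyl alone. The earlier pair, methyl against ethyl ester, could not separate these two parts of the change.

As far as these compounds go, whether a carboxylic acid, a primary amide or an amine at this position would fit with the acetyl or with the ester remains open. Nothing among the available measurements bears on why these steps differ in size.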